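Replacing a hydroxyethyl cap with an acetyl cap

A few compounds are considered here, and "the series" means these few. Any claim that something is new, unique, unknown or untested is made for them only; others in the source may bear on it.

Of the compounds shown here, three sharing one core have been measured in an assay on RBL-1 cells with Polyunsaturated fatty acid 5-lipoxygenase (Rattus norvegicus) as the target; a lower number here means a stronger inhibitor, a higher number a weaker inhibitor. Compound 1 `Cc1ccc(Cc2ccc3ccccc3c2O)cc1` gives 24 nM. Compound 2 `COc1c(Cc2ccccc2)ccc2ccccc12`, in which the oxygen on the ring carries a methyl group, gives 55000 nM. Compound 3 `OCCOc1c(Cc2ccccc2)ccc2ccccc12`, in which that oxygen carries a 2-hydroxyethyl group, gives 40000 nM. Compound 3 therefore stands second highest of the three numbers: its value sits within the scatter of compound 2, while compound 1 lies far lower, beyond the scatter.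

The next compound, compound 4 `CC(=O)Oc1c(Cc2ccccc2)ccc2ccccc12`, differs from compound 3 in one place: acetyl in place of 2-hydroxyethyl on an oxygen on an aromatic ring. Going by the values given here, the only measured step that bears on this change is a 1.4-fold lower number from compound 2 to compound 3 (0.14 log units; within the scatter), which shows that swapping one small group for another on this oxygen left this assay essentially unchanged. Among the compounds with values here, compound 1, the only compound whose ring oxygen carries no group at all, is the one with the low number, and compound 4 still carries a group on that oxygen.

On this basis, compound 4 is expected to show no change at the digits printed from compound 3 to compound 4 (within the scatter), a shift that stays within the scatter. The estimate for compound 4 in this assay is 40000 nM, with a range from 8000 nM to 200000 nM.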

Compound 4, half-maximal inhibitory concentration: 140 nM
Compound 4: middle estimate off by 290-fold (2.46 log units), on the high side; measured number outside the range, below it.
By their numbers in this assay, from the lowest: compound 1; then compound 4; then compounds 3 and 2 (each within the scatter of the next).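

In this assay, going by these compounds alone, acetyl in place of 2-hydroxyethyl gives a 290-fold lower number from compound 3 to compound 4 (2.46 log units; beyond the scatter), and acetyl in place of methyl gives a 390-fold lower number from compound 2 to compound 4 (2.59 log units; beyond the scatter), so this oxygen is far more sensitive to what it carries than the earlier compounds suggested. Within the data shown here, until now, the only swap at this position, from methyl to 2-hydroxyethyl, had stayed within the scatter, but compound 4 shows that a group on this oxygen does not by itself keep the number high. The 2-hydroxyethyl and acetyl groups have the same count of heavy atoms, so that count does not separate compound 3 from compound 4, and nothing measured here explains the size of this step.

As far as these compounds go, it remains open whether the effect belongs to acetyl alone or extends to related groups on this oxygen, such as propionyl, with its longer chain, benzoyl or dimethylcarbamoyl. From the compounds shown here alone, it is also open what acetyl would do on the core of compound 1, which differs from compound 4 in more than the group on this oxygen.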